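The source may report more compounds than this note shows. Statements on the series, on what has been measured and on what is new or still open speak of the compounds shown alone.

Compounds measured in a functional assay on A549 cells (Homo sapiens) for antiproliferative activity, read by MTT assay, with a stated time of 72 h; on this read-out higher numbers stand for weaker inhibition and lower numbers for stronger inhibition:
compound 1 `O=C1O/C(=C\Cn2cc(-c3cc(F)cc(F)c3)nn2)C(OCc2ccccc2)=C1OCc1ccccc1`: > 100000 nM
compound 2 `COc1ccccc1-c1cn(C[C@H](O)[C@H]2OC(=O)C(OCc3ccccc3)=C2OCc2ccccc2)nn1`: > 100000 nM

In this assay compound 1 gives only a limit of the assay, > 100000 nM. Compound 2 likewise gives only a limit, > 100000 nM. Compound 1 thus stands at the limit of > 100000 nM in this assay, at which 2 of the 2 values shown sit. Compound 3 `O=C1O/C(=C\Cn2cc(-c3cccc(O)c3)nn2)C(OCc2ccccc2)=C1OCc1ccccc1` differs from compound 1 in one place: 3-hydroxyphenyl in place of 3,5-difluorophenyl on an aromatic carbon. Among the measured compounds shown here, no step between measured compounds is known here, so any expectation rests on compound 1 alone. The step of a number no higher from compound 1 to compound 3 (the limit leaves the size open) is expected to stay within the usual scatter, with no change in direction. Compound 3 is accordingly estimated at 100000 nM, with a range from 30000 nM to 300000 nM.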

Compound 3, half-maximal inhibitory concentration: 23300 nM
Compound 3: the middle estimate sits 4.3-fold (0.63 log units) above what was measured, and the stated range ends above it.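

On the ring attached to the five-membered aromatic ring, this change does move the read-out: in this assay, 3-hydroxyphenyl in place of 3,5-difluorophenyl gives an at least 4.2-fold lower number from compound 1 to compound 3 (0.63 log units; beyond the scatter). Compound 3 thus provides a measured number, so this position can alter the result. The other values shown are limits of the assay, not numbers: the limit of > 100000 nM in this assay, at which 2 of the 3 values shown sit.

The change removes the fluorines and adds a hydroxyl, so the compounds shown cannot separate these two parts. As far as these compounds go, whether a 3-aminophenyl or 3-carboxyphenyl group would behave like 3-hydroxyphenyl also stays open.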